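Quinazoline diamines at a single concentration on chemokine receptor type 4

This account rests on a few compounds, and the source may have more. Where it says the series, first, only, none or still open, it means among the compounds named here.

Compound 1 `COc1cc2nc(NCc3ccccc3)nc(NC3CCCCCC3)c2cc1OC`: < 0%
Compound 2 `c1ccc2c(NC3CCCCCC3)nc(N3CCC(N4CCCC4)CC3)nc2c1`: 0%
Compound 3 `COc1cc2nc(N3CCC(Cc4ccccc4)CC3)nc(NC3CCCCCC3)c2cc1OC`: < 0%

In an in vitro assay on B300-19 cells for displacement of a labelled ligand from C-C chemokine receptor type 4 (Homo sapiens), tested at 1 uM (a higher number here means more inhibition at the concentration tested (going by the name of the read-out), a lower number less inhibition), compound 1 gives < 0%, which is a limit of the assay and not a number. Compound 3 likewise gives only a limit, < 0%. Compound 2 gives 0% in this assay. Compound 1 thus stands at the limit of < 0% in this assay, at which 2 of the 3 values shown sit, and none of the three shows inhibition beyond the scatter. Compound 4 `COc1cc2nc(NCCCN3CCCC3=O)nc(NC3CCCCCC3)c2cc1OC` differs from compound 1 by 2-(2-oxopyrrolidin-1-yl)ethyl in place of phenyl on a saturated chain carbon bound to a nitrogen on an aromatic ring. Among the measured compounds shown here, no measured pair shows a step of this kind, so no change beyond the scatter is expected from compound 1 to compound 4 in this assay. Compound 4 is therefore estimated at 2%, within -10% to 15%. This estimate means a step of a number at least 2 percentage points higher from compound 1 to compound 4 (that floor lies within the scatter), expected to stay within the scatter.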

Compound 4, a percentage reported as inhibition, at one concentration (the size of the read-out at that concentration, not a potency): 8%
Estimate against measurement, compound 4: 6 percentage points below; the range from low to high includes it.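

In this assay, among the compounds shown here, the exchange of phenyl for 2-(2-oxopyrrolidin-1-yl)ethyl on a saturated chain carbon bound to a nitrogen on an aromatic ring gives a number at least 8 percentage points higher from compound 1 to compound 4 (that floor lies within the scatter) and provides the first step that can be read at this place. The value for compound 1 is a limit of the assay, so the step has a floor and no exact size. That floor rests on the limit shared with another compound: the limit of < 0% in this assay, at which 2 of the 4 values shown sit.

Going by these compounds, what an amine or a carboxylic acid would give in place of the 2-(2-oxopyrrolidin-1-yl)ethyl remains open. So does whether any group at this place can lift inhibition beyond the scatter.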